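Fluoro in place of methyl on the hydroxy-bearing ring

The source may report more compounds than this note shows. Statements on the series, on what has been measured and on what is new or still open speak of the compounds shown alone.

Of the compounds shown here, three sharing one core have been tested in a functional assay on KG-1 cells (Homo sapiens) for cytotoxicity, read by luminescence and CellTiter-Glo, with a stated time of 3 days; on this read-out higher numbers stand for weaker inhibition and lower numbers for stronger inhibition. Compound 1 `N#Cc1ccc(NC(=O)c2cc(-c3ccncc3)ccc2O)cc1` gives 7990 nM. Compound 2 `COc1cccc(C(=O)Nc2ccc(C#N)cc2)c1O` reaches only a limit of the assay, > 10000 nM. Compound 3 `Cc1cccc(C(=O)Nc2ccc(C#N)cc2)c1O` gives 8980 nM, the higher of the two numbers, with compound 1 nearest to it and within the scatter. Within the data shown here, the one measured step, an at least 1.1-fold lower number from compound 2 to compound 3 (0.04 log units; that floor lies within the scatter), cannot be sized beyond its floor because compound 2 sits at the limit of > 10000 nM in this assay, at which 1 of the 3 values shown sits, so the only evidence on a change at this ring position is that it did not move the number clearly.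

Compound 4 `N#Cc1ccc(NC(=O)c2cccc(F)c2O)cc1` has not yet been measured. It differs from compound 3 by fluoro in place of methyl on an aromatic carbon. The step that bears on it, an at least 1.1-fold lower number from compound 2 to compound 3 (0.04 log units; that floor lies within the scatter), was no larger than the scatter, so a change of similar character is expected to leave the number roughly where compound 3 stands. For compound 4 the expected value in this assay is 9000 nM, within 4000 nM to 20000 nM. This means an expected 1.0-fold higher number from compound 3 to compound 4 (0.00 log units; within the scatter), not beyond the scatter.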

Compound 4, half-maximal inhibitory concentration: 9690 nM
Estimate against measurement, compound 4: 1.1-fold (0.03 log units) below, within the range that was stated.
By their numbers in this assay, from the lowest: compounds 1, 3 and 4 (each within the scatter of the next). At a limit, above all of these: compound 2.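

Fluoro in place of methyl on this carbon, ortho to a hydroxy group, gives a 1.1-fold higher number from compound 3 to compound 4 (0.03 log units; within the scatter) in this assay, a change within the scatter of repeated measurements. Unlike the earlier step, this one joins two measured numbers, so it has a true size and not just a floor: swapping methyl for fluoro here does not clearly move the number. The step from methoxy gives only a floor, an at least 1.0-fold lower number from compound 2 to compound 4 (0.01 log units; that floor lies within the scatter), and cannot be sized further because compound 2 sits at a limit of the assay: the limit of > 10000 nM in this assay, at which 1 of the 4 values shown sits.

The compounds shown therefore do not reveal whether any group on this carbon can clearly shift the number. From the compounds shown here alone, whether an amine, a carboxylic acid or a longer chain here would move it beyond the scatter stays open.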